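Swapping a tolyl for a cyanopyridyl on the shared core

A few compounds are considered here, and "the series" means these few. Any claim that something is new, unique, unknown or untested is made for them only; others in the source may bear on it.

Of the compounds shown here, three sharing one core have been measured in an assay on isolated protein for inhibition of G protein-coupled receptor kinase 6 (Homo sapiens), read by scintillation counting, radiometric assay and 33P incorporation, with a stated time of 80 min, in the presence of a further agent that is not named here; a higher number here means a weaker inhibitor, a lower number a stronger inhibitor. Compound 1 `CCc1cc(Nc2nc(N[C@@H](C)c3ccc(F)cc3)nc3ccccc23)n[nH]1` gives 120 nM in this assay. Compound 2 `CCc1cc(Nc2nc(N[C@@H](C)c3ccc(C)cc3)nc3cccc(F)c23)n[nH]1` gives 27 nM in this assay. Compound 3 `CCc1cc(Nc2nc(NCc3ccc(Cl)cc3OC)nc3cccc(C)c23)n[nH]1` gives 6 nM in this assay. Among these numbers compound 2 stands second highest: the nearest is compound 1, whose higher number lies beyond the scatter, and the furthest is compound 3, whose lower number also lies beyond the scatter.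

Compound 4 `CCc1cc(Nc2nc(N[C@@H](C)c3ccc(C#N)cn3)nc3cccc(F)c23)n[nH]1` has not been measured. It differs from compound 2 in one place: 5-cyanopyridin-2-yl in place of 4-methylphenyl on a saturated chain carbon bound to a nitrogen on an aromatic ring and a saturated chain carbon. For the measured compounds named here, no measured pair in this set isolates that change, so nothing here shows how this assay responds to it. The three measured compounds differ from one another in more than one place, and only their values are known, not any single step.

Going by the values given here, with no direct precedent, the expected step of a 1.9-fold higher number from compound 2 to compound 4 (0.27 log units; within the scatter) in this assay is toward a somewhat higher number, but of a size that may not clear the scatter. Compound 4 is therefore estimated to give 50 nM in this assay, within a range from 15 nM to 200 nM.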

Compound 4, half-maximal inhibitory concentration: 91 nM
Compound 4: the middle estimate sits 1.8-fold (0.26 log units) below what was measured; the range from low to high includes it.
By their numbers in this assay, from the lowest: compound 3; then compound 2; then compounds 4 and 1 (each within the scatter of the next).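

In this assay, placing 5-cyanopyridin-2-yl in place of 4-methylphenyl on a saturated chain carbon bound to a nitrogen on an aromatic ring and a saturated chain carbon gives a 3.4-fold higher number from compound 2 to compound 4 (0.53 log units; beyond the scatter) in this set. For the compounds shown here, this is the first single-place step available, and it shows that this position responds to the group it carries, with this replacement leading to a weaker inhibitor. No measured information here bears on why the number rises, so the step stands as an observation without an explanation.

The step changes the ring and brings in the nitrile together, so the compounds shown leave open how much of it belongs to each, a question that 4-cyanophenyl or plain pyridin-2-yl at this position would separate. Also open, on these data alone, is whether the same swap would have a similar effect with the other substitution patterns seen on the shared core, and how other groups at this position, such as 4-methoxyphenyl or a saturated piperidine ring, would compare with 4-methylphenyl.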